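The source may report more compounds than this note shows. Statements on the series, on what has been measured and on what is new or still open speak of the compounds shown alone.

Compound 1 `c1ccc(CNCC2CCN(CCCc3c[nH]c4ccc(-n5cnnc5)cc34)CC2)cc1`: 101%
Compound 2 `c1ccc(C2CCCCN2C2CCN(CCCc3c[nH]c4ccc(-n5cnnc5)cc34)CC2)cc1`: 65%
Compound 3 `CC(=O)Nc1ccc([C@H](C)NCC2CCN(CCCc3c[nH]c4ccc(-n5cnnc5)cc34)CC2)cc1`: 99%

In a functional assay on CHO cells for activation of 5-hydroxytryptamine receptor 1D (Homo sapiens), read by GTPgammaS binding (a lower number here means a smaller maximal response, a higher number a larger maximal response), compound 1 gives 101%, the highest of the three numbers, though compound 3 sits within the scatter of it. Compound 3 gives 99%; the step of a number 2 percentage points lower from compound 1 to compound 3 (within the scatter) shows that 1-(4-acetamidophenyl)ethyl in place of benzyl on the amine nitrogen leaves the maximal response unchanged. For the measured compounds named here, compound 2 gives 65%, a number beyond the scatter below compound 1; compound 2 differs from compound 1 in more than one place, so no single step is stated for that pair.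

Compound 4 `CN(Cc1ccsc1)C1CCN(CCCc2c[nH]c3ccc(-n4cnnc4)cc23)CC1` is not yet measured in this assay. Relative to compound 1 the change is methyl((thiophen-3-yl)methyl)amino in place of (benzylamino)methyl on a saturated ring carbon. Going by the values given here, the only single measured step, from compound 1 to compound 3, alters the substituent on the amine nitrogen and was flat; it does not cover placing the amino nitrogen on the saturated ring carbon. Compound 2, which also bears its amine nitrogen on the saturated ring carbon, gives 65%, the lowest number seen. A lower maximal response is therefore expected for compound 4, a number 16 percentage points lower from compound 1 to compound 4 (beyond the scatter), with wide uncertainty. The estimate for compound 4 is 85%, expected to fall between 65% and 105%.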

Compound 4, largest response reached (reported as efficacy), in percent of the reference or control that the assay uses: 93%
Beside the measured number, compound 4's estimate is 8 percentage points below it; the range from low to high includes it.
By their numbers in this assay, from the lowest: compound 2; then compounds 4, 3 and 1 (each within the scatter of the next).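

In this assay, the step of a number 8 percentage points lower from compound 1 to compound 4 (within the scatter) shows that the maximal response holds when methyl((thiophen-3-yl)methyl)amino replaces (benzylamino)methyl on the saturated ring carbon, even though the change exchanges the six-membered aromatic ring of carbon only for a five-membered aromatic ring with a hetero atom and loses the hydrogen-bond donor. An amine nitrogen on that ring carbon therefore does not by itself go with the value of compound 2 (65%), which bears a different group there. No measurement on hand offers an explanation for this result.

The compounds shown do not separate the contributions of the nitrogen methyl, the thiophene and the shift of the amine nitrogen onto the ring carbon. Going by these compounds, how a pyridinylmethyl group on that same amine nitrogen would read also remains open.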